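Phenyl for methyl at the limit of the assay

The source may hold more compounds than are shown below. What is called first, only, known or untested is meant among the compounds shown, and "the series" means these compounds.

In a functional assay on HEp-2 cells (Homo sapiens) for antiproliferative activity, read by MTT assay, with a stated time of 72 h (on this read-out lower numbers stand for stronger inhibition and higher numbers for weaker inhibition), compound 2 (`CN1CCN(/C=C2\Oc3ccccc3C2=O)CC1`) reads > 50000 nM as a limit and not a number. Compound 3 (`CN1CCN(/C=C2\Oc3ccccc3C2=O)C(c2ccccc2)C1`) reads > 50000 nM as a limit too. Compound 1 (`Cc1nnc(Sc2coc3ccccc3c2=O)o1`) reads > 50000 nM as a limit as well. All three share the limit of > 50000 nM in this assay, at which 3 of the 3 values shown sit, and none gives a number to start from.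

Compound 4 (`O=C1/C(=C/N2CCN(c3ccccc3)CC2)Oc2ccccc21`) differs from compound 2 by phenyl in place of methyl on an amine nitrogen in a ring with phenyl in place of methyl on an amine nitrogen in a ring. Within the data shown here, the one measured step bearing on this is a step that the two limits leave unreadable from compound 2 to compound 3 where phenyl replaces hydrogen on a saturated ring carbon. No step beyond the scatter is therefore expected in this assay in either direction. The expected step is a number no higher from compound 2 to compound 4 (the limit leaves the size open) on this estimate. Compound 4 is estimated at 50000 nM with an expected range from 20000 nM to 100000 nM in this assay.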

Compound 4, half-maximal inhibitory concentration: 27700 nM
Estimate against measurement, compound 4: 1.8-fold (0.26 log units) above, and the stated range covers the measured number.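

On the amine nitrogen in the ring, phenyl in place of methyl gives the only actual number among the compounds shown in this assay, while the others stay at a limit: the limit of > 50000 nM in this assay, at which 3 of the 4 values shown sit. The change reads as an at least 1.8-fold lower number from compound 2 to compound 4 (0.25 log units; that floor lies within the scatter) and the limit on compound 2 leaves its full size open.

As far as these compounds go, whether a benzyl group or a pyridine ring on that nitrogen would read like phenyl stays open. So does whether chlorine on the phenyl ring would move the number beyond the scatter.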